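Ether side-chain exchange on compound 2: notes for compound 4

The source may hold more compounds than are shown below. What is called first, only, known or untested is meant among the compounds shown, and "the series" means these compounds.

Measured in an ADME assay on HeLa cells (Homo sapiens) for cytotoxicity, read by MTT assay; on this read-out higher numbers stand for weaker inhibition and lower numbers for stronger inhibition:
- compound 1 `COc1ccc(C[C@H]2COC(=O)[C@@H]2Cc2ccc(OCc3cn(Cc4ccc(Cl)cc4)nn3)c(OC)c2)cc1OC`: 242000 nM
- compound 2 `CCN(CC)C(=O)CCC(=O)Oc1ccc(C[C@H]2C(=O)OC[C@@H]2Cc2ccc(OC)c(OC)c2)cc1OC`: 213000 nM
- compound 3 `COC(=O)[C@H](CCSC)NC(=O)CCC(=O)Oc1ccc(C[C@H]2C(=O)OC[C@@H]2Cc2ccc(OC)c(OC)c2)cc1OC`: 199000 nM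

Compound 2 holds the second highest of the three numbers; its nearest neighbour is compound 3 and its furthest is compound 1, both within the scatter of it. Compound 4 `COc1ccc(C[C@H]2COC(=O)[C@@H]2Cc2ccc(OCC(=O)N3CCOCC3)c(OC)c2)cc1OC` differs from compound 2 as follows: a group of 9 heavy atoms (6 carbon, 1 nitrogen, 2 oxygen; one six-membered non-aromatic ring with 2 hetero atoms) in place of a group of 11 heavy atoms (8 carbon, 1 nitrogen, 2 oxygen; no ring), on an oxygen on an aromatic ring. For the measured compounds named here, the one step measured, a 1.1-fold lower number from compound 2 to compound 3 (0.03 log units; within the scatter), also reworks the chain on that aromatic oxygen and stays within the scatter; compound 1, with another chain on the same oxygen, lies within the scatter of compound 2 as well. No step beyond the scatter is therefore expected in this assay. Compound 4 is estimated at 215000 nM, range 100000 nM to 460000 nM, meaning an expected step of a 1.0-fold higher number from compound 2 to compound 4 (0.00 log units; within the scatter).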

Compound 4, half-maximal inhibitory concentration: >= 600000 nM
Compound 4: a limit, no number; the forecaster's own chance of this, stated with the estimate: 15%; at least 2.7-fold (0.44 log units) between middle value and limit.
By their numbers in this assay, from the lowest: compounds 3, 2 and 1 (each within the scatter of the next). At a limit, above all of these: compound 4.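

In this assay, for the compounds shown here, the ((morpholin-4-yl)carbonyl)methyl group on this aromatic oxygen gives the first change that moves beyond the scatter, with an at least 2.8-fold higher number from compound 2 to compound 4 (0.44 log units; beyond the scatter), whereas a 1.1-fold lower number from compound 2 to compound 3 (0.03 log units; within the scatter). Going by these compounds alone, the chain on this oxygen can therefore shift the read-out, which the earlier compounds did not show. Compound 4 stands at a limit of the assay, not at a number: the limit of >= 600000 nM in this assay, at which 1 of the 4 values shown sits.

As far as these compounds go, how far compound 4 lies past that limit stays open. Also open, from the compounds shown here alone, is how a piperazine amide or a carboxylic acid on the same oxygen would read.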